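The source may hold more compounds than are shown below. What is called first, only, known or untested is meant among the compounds shown, and "the series" means these compounds.

In an in vitro ADME assay on microsomes from liver (Mus musculus) for pharmacokinetics, read by LC-MS, with a stated time of 10 min, tested at 1 uM (a lower number here means slower removal, a higher number faster removal of the compound), compound 1 (`COc1cccc(NC(=O)[C@H]2CN(C)C[C@@H]2c2ccc(/C=C/C(=O)Nc3ccccc3N)cc2)c1`) gives 65 mL/min/kg and compound 2 (`CC(C)(CO)N1C[C@H](C(=O)Nc2ccc(Cl)cc2)[C@@H](c2ccc(/C=C/C(=O)Nc3ccccc3N)cc2)C1`) gives 40 mL/min/kg. These two numbers lie within the usual scatter of each other, so compound 2 cannot be separated from compound 1 on this evidence. Compound 3 (`Nc1ccccc1NC(=O)/C=C/c1ccc([C@H]2CN(c3ncccn3)C[C@@H]2C(=O)Nc2ccc(Cl)cc2)cc1`) has yet to be measured in this assay. It departs from compound 2 in one place, on an amine nitrogen in a ring, where it carries pyrimidin-2-yl in place of 1-(hydroxymethyl)-1-methylethyl (pyrimidin-2-yl in place of 1-(hydroxymethyl)-1-methylethyl on an amine nitrogen in a ring). Among the measured compounds shown here, the two measured compounds differ from each other in more than one place, and no measured pair isolates this change, so the data give no direct guide to its effect. The expectation therefore starts from compound 2 at 40 mL/min/kg and stays cautious. The expected 1.3-fold higher number from compound 2 to compound 3 (0.11 log units; within the scatter) remains within the scatter, with only a slight lean towards faster removal. For compound 3 the estimate is 52 mL/min/kg, with an expected range from 26 mL/min/kg to 100 mL/min/kg.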

Compound 3, clearance: 44 mL/min/kg
Beside the measured number, compound 3's estimate is 1.2-fold (0.07 log units) above it; the measured number falls inside the stated range.
By their numbers in this assay, from the lowest: compounds 2, 3 and 1 (each within the scatter of the next).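

Among the compounds shown here, the step from compound 2 gives the first reading of a single change on the amine nitrogen in a ring, where pyrimidin-2-yl takes the place of 1-(hydroxymethyl)-1-methylethyl: in this assay it amounts to a 1.1-fold higher number from compound 2 to compound 3 (0.04 log units; within the scatter). The group that leaves has no ring and 1 hydrogen-bond donor, while the group that enters is a six-membered aromatic ring with 2 hetero atoms and 0 hydrogen-bond donors, yet this pair cannot be told apart by its clearance in this assay, so at this position, with the (4-chlorophenyl)carbamoyl group held constant, the exchange leaves no readable mark. No independent measurement bears on this result.

Still open, as far as these compounds go, is whether a different group on the same nitrogen, such as a primary amine chain, a carboxylic acid or a longer alkyl chain, would give a step beyond the scatter in this assay. Also open, from the compounds shown here alone, is whether pyrimidin-2-yl in place of 1-(hydroxymethyl)-1-methylethyl would read the same with another amide group on the shared core.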